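The source may hold more compounds than are shown below. What is called first, only, known or untested is meant among the compounds shown, and "the series" means these compounds.

Working notes on the amide series built on the shared core of compound 1 `Nc1sc(-c2ccc(Cl)cc2)c(-c2ccc(Cl)cc2)c1C(=O)N1CCCC1`, compared in a functional assay on A549 cells (Homo sapiens) for inhibition, read by sulforhodamine B assay, with a stated time of 72 h; a higher number here means a weaker inhibitor, a lower number a stronger inhibitor. In this assay, among the compounds with values here, compound 1 gives 890 nM, the lowest of the three numbers so far. Compound 2 `Nc1sc(-c2ccc(Cl)cc2)c(-c2ccc(Cl)cc2)c1C(=O)N1CCC(=O)CC1=O` gives 4090 nM and compound 3 `Nc1sc(-c2ccc(Cl)cc2)c(-c2ccc(Cl)cc2)c1C(=O)NC1CC1` gives 1950 nM. Both changes at the carbonyl carbon raised the number: a 4.6-fold higher number from compound 1 to compound 2 (0.66 log units; beyond the scatter) and a 2.2-fold higher number from compound 1 to compound 3 (0.34 log units; beyond the scatter). Compound 4 `CC1CCN(C(=O)c2c(N)sc(-c3ccc(Cl)cc3)c2-c2ccc(Cl)cc2)CC1` differs from compound 1 at the same place: 4-methylpiperidin-1-yl in place of pyrrolidin-1-yl on a carbonyl carbon. Neither measured step covers this exactly; a saturated ring amide remains, as in compound 1, so a step no larger than that of compound 3 is expected, towards a higher number or none beyond the scatter. Compound 4 is therefore estimated at 1200 nM, within 500 nM to 3000 nM. The expected step is a 1.3-fold higher number from compound 1 to compound 4 (0.13 log units; within the scatter).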

Compound 4, half-maximal inhibitory concentration: 1750 nM
For compound 4 the middle estimate is 1.5-fold (0.16 log units) below the measured one, within the range that was stated.
By their numbers in this assay, from the lowest: compounds 1, 4 and 3 (each within the scatter of the next, the first and the last beyond it); then compound 2.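

In this assay, the six-membered 4-methylpiperidin-1-yl ring on the carbonyl carbon cannot be told apart from the pyrrolidin-1-yl ring (a 2.0-fold higher number from compound 1 to compound 4 (0.29 log units; within the scatter)). It also cannot be told apart from cyclopropylamino (a 1.1-fold lower number from compound 3 to compound 4 (0.05 log units; within the scatter)), while 2,4-dioxopiperidin-1-yl remains beyond the scatter of all three (a 2.3-fold lower number from compound 2 to compound 4 (0.37 log units; beyond the scatter)). No evidence at hand accounts for these steps.

The compounds shown leave open how a morpholin-4-yl or piperazin-1-yl amide would read here. They also leave open whether the ring size and the methyl group count separately, which piperidin-1-yl would address.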